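The compounds below may be only part of what the source reports. "The series", "measured", "known", "first", "only" and "open" are said of these compounds alone.

Measured compounds:
- compound 1 `C#CCNC1CCc2c(OCCCCCN3CCN(c4cccc5c4ccn5Cc4cccc(Cl)c4)CC3)cccc21` — 223 nM
- compound 2 `C#CCNC1CCc2c(OCCCCCCN3CCN(c4cccc5c4ccn5Cc4cccc(Cl)c4)CC3)cccc21` — 259 nM

Both compounds were tested in an assay on HEK293 cells for displacement of a labelled ligand from 5-hydroxytryptamine receptor 6 (Homo sapiens), read by scintillation counting, with a stated time of 1 h; on this read-out higher numbers stand for weaker inhibition and lower numbers for stronger inhibition. Compound 1 gives 223 nM and compound 2 gives 259 nM; the two values lie within the scatter of each other, so neither can be called the stronger binder and no ordering is drawn from them. Compound 1 is simply the lower of the two numbers.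

The next compound, compound 3 `C#CCNC1CCc2c(OCCCCCN3CCN(c4cccc5c4ccn5S(=O)(=O)c4ccccc4)CC3)cccc21`, is not yet measured in this assay. Relative to compound 1 the change is phenylsulfonyl in place of 3-chlorobenzyl on an aromatic nitrogen; the rest of the shared core of compound 1, including the five-carbon linker and the piperazine, is kept.

Among the compounds with values here, no measured pair isolates this change, so there is no step to compare against. The expectation is therefore weakly founded. A moderate step in this assay is expected, towards a lower number, but one that could also fall within the scatter of compound 1 at 223 nM. For compound 3 the estimate in this assay is 100 nM, with a range from 25 nM to 400 nM, corresponding to an expected step of a 2.2-fold lower number from compound 1 to compound 3 (0.35 log units; beyond the scatter).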

Compound 3, inhibition constant: 51 nM
Compound 3: middle estimate off by 2.0-fold (0.29 log units), on the high side; the range from low to high includes it.
By their numbers in this assay, from the lowest: compound 3; then compounds 1 and 2 (each within the scatter of the next).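

In this assay, the group on the aromatic nitrogen of the five-membered aromatic ring affects the read-out: phenylsulfonyl in place of 3-chlorobenzyl gives a 4.4-fold lower number from compound 1 to compound 3 (0.64 log units; beyond the scatter), with the rest of the shared core kept. Within the data shown here, compound 1 and compound 2 both carry 3-chlorobenzyl, so they gave no reading of this position; this step is the first, and it shows that the position is responsive to the exchange of one group for the other. The exchange alters several things at once, removing the chlorine and bringing in two hydrogen-bond acceptors and two double bonds outside aromatic rings, and no measurement on hand bears on which of these matters.

Open, as far as these compounds go, is whether the step belongs to the sulfonyl link or to the loss of the chlorine, a question that plain benzyl and 3-chlorophenylsulfonyl on the same nitrogen would separate. Also open, from the compounds shown here alone, is whether phenylsulfonyl gives a comparable step on the longer chain of compound 2, and how a small group such as methyl at this nitrogen would read.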